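The source may hold more compounds than are shown below. What is called first, only, known or untested is meant among the compounds shown, and "the series" means these compounds.

Compound 1 `N#CC1=C(N)Oc2c(c3nc4ccccc4nc3c3ccccc23)C12C(=O)N(Cc1cnnn1-c1ccc(Cl)cc1)c1ccccc12` belongs to a small set built on one shared core. In a functional assay on HCT-116 cells (Homo sapiens) for antiproliferative activity, read by MTT assay, with a stated time of 48 h (on this read-out lower numbers stand for stronger inhibition and higher numbers for weaker inhibition), compound 1 gives only a limit of the assay, > 50000 nM. Compound 2 `N#CC1=C(N)Oc2c(c3nc4ccccc4nc3c3ccccc23)C12C(=O)N(Cc1cnnn1-c1ccccc1Cl)c1ccccc12` is its near relative; in this assay compound 2 likewise returns only a limit, > 50000 nM. The connecting step that the two limits leave unreadable from compound 1 to compound 2 is therefore not readable. Compound 3 `N#CC1=C(N)Oc2c(N)cc3nc4ccccc4nc3c2C12C(=O)N(Cc1cnnn1-c1ccccc1Cl)c1ccccc12` differs from compound 2 elsewhere on the shared core; in this assay compound 3 also gives only a limit, > 50000 nM. Every measured value sits at the limit of > 50000 nM in this assay, at which 3 of the 3 values shown sit, so compound 3 stands nowhere within a readable range but at the same limit as the rest.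

Compound 4 `CCOc1ccc(-n2nncc2CN2C(=O)C3(C(C#N)=C(N)Oc4c(N)cc5nc6ccccc6nc5c43)c3ccccc32)cc1` differs from compound 3 in one place: 4-ethoxyphenyl in place of 2-chlorophenyl on an aromatic nitrogen. Going by the values given here, the one measured step at this same aromatic nitrogen, a step that the two limits leave unreadable from compound 1 to compound 2, lies between two limits and yields no size, so no measured step offers a direction for this change. With all measured values at the limit, no shift beyond the scatter is expected for compound 4 in this assay. The step from compound 3 to compound 4 is estimated as a step that the limit leaves unreadable from compound 3 to compound 4. Compound 4 is accordingly expected near 60000 nM in this assay, within 20000 nM to 200000 nM, and most probably reported again only as a limit.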

Compound 4, half-maximal inhibitory concentration: > 50000 nM
Compound 4: only a limit was reported; the forecaster's own chance of this, stated with the estimate: 85%; the middle value lies beyond the limit too.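

Compound 4 returns only a limit in this assay, > 50000 nM. Going by these compounds alone, compound 3 is likewise known only as a limit, so no step between compound 3 and compound 4 can be read. The compounds shown leave open whether any change on the shared core shifts antiproliferative activity at all, as every value stands at one point: the limit of > 50000 nM in this assay, at which 4 of the 4 values shown sit.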